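Ring nitrogen substituent: acetyl versus methyl

The source may hold more compounds than are shown below. What is called first, only, known or untested is meant among the compounds shown, and "the series" means these compounds.

For the measured compounds named here, compound 3 `COc1ccc(F)c(-c2ccc3c(NC(=O)c4ccc(N5CCN(C(C)=O)CC5)cc4)n[nH]c3c2)c1F` gives 595 nM in a functional assay on KG-1 cells (Homo sapiens) for antiproliferative activity, read by CCK-8 assay, with a stated time of 72 h (on this read-out higher numbers stand for weaker inhibition and lower numbers for stronger inhibition), the highest of the three numbers measured so far; compound 1 `COc1ccc(F)c(-c2ccc3c(NC(=O)c4ccc(N(C)CCN(C)C)cc4)n[nH]c3c2)c1F` gives 333 nM and compound 2 `COc1ccc(F)c(-c2ccc3c(NC(=O)c4ccc(N5CCCN(C)CC5)cc4)n[nH]c3c2)c1F` gives 51.5 nM. Compound 4 `COc1ccc(F)c(-c2ccc3c(NC(=O)c4ccc(N5CCN(C)CC5)cc4)n[nH]c3c2)c1F` differs from compound 3 by methyl in place of acetyl on an amine nitrogen in a ring. Going by the values given here, no measured step swaps acetyl for methyl on the same ring. The nearest comparisons are a 12-fold higher number from compound 2 to compound 3 (1.06 log units; beyond the scatter) and a 6.5-fold lower number from compound 1 to compound 2 (0.81 log units; beyond the scatter), both of which leave compound 2, carrying the 4-methyl-1,4-diazepan-1-yl group, at the lowest number. A step toward a lower number is therefore expected, estimated as a 6.0-fold lower number from compound 3 to compound 4 (0.77 log units; beyond the scatter), though the exact size is uncertain. Compound 4 is expected to give about 100 nM in this assay, within 35 nM to 300 nM.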

Compound 4, half-maximal inhibitory concentration: 41.5 nM
Compound 4: the middle estimate sits 2.4-fold (0.38 log units) above what was measured; the range from low to high includes it.
By their numbers in this assay, from the lowest: compounds 4 and 2 (each within the scatter of the next); then compounds 1 and 3 (each within the scatter of the next).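

On the six-membered ring itself, in this assay, methyl in place of acetyl on the amine nitrogen gives a 14-fold lower number from compound 3 to compound 4 (1.16 log units; beyond the scatter), so the acetyl-to-methyl change now has a direct reading with nothing else altered. Changing the ring size of the methylated amine does not separate the two compounds, with a 1.2-fold lower number from compound 2 to compound 4 (0.09 log units; within the scatter). The ring also stands clear of the open chain, with an 8.0-fold lower number from compound 1 to compound 4 (0.90 log units; beyond the scatter).

The compounds shown give no evidence for why the acetyl and methyl compounds differ. Open, from the compounds shown here alone, is how an ethyl, a 2-hydroxyethyl or an unsubstituted amine on the same ring nitrogen would read.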